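Swapping the acetyl on the ring nitrogen for a nitroso group

This account rests on a few compounds, and the source may have more. Where it says the series, first, only, none or still open, it means among the compounds named here.

Compound 1, `Cc1nn(C)c2c1C(c1ccccc1)=NCCN2`, and compound 2, `Cc1nn(C)c2c1C(c1ccccc1)=NCCN2C`, share one core. In a functional assay on the whole organism for positive allosteric modulation, with Rattus norvegicus as the target (a higher number here means that more compound is needed for the effect, a lower number that less compound is needed), compound 1 gives 2.5 mg/kg. Compound 2 gives 2.5 mg/kg. Among the compounds with values here, the only measured step is no change at the digits printed from compound 1 to compound 2 (within the scatter), so a small group on that ring nitrogen left the minimum effective dose where it was. Compound 3, `CC(=O)N1CCN=C(c2cccc(Cl)c2)c2c(C)nn(C)c21`, carries an acetyl on the same ring nitrogen and a 3-chlorophenyl group. For compound 3 this assay reports no number, only the limit > 10 mg/kg; this is the limit of > 10 mg/kg in this assay, at which 1 of the 3 values shown sits. Compound 4, `Cc1nn(C)c2c1C(c1cccc(Cl)c1)=NCCN2N=O`, differs from compound 3 by a group of 2 heavy atoms (1 nitrogen, 1 oxygen; no ring) in place of a group of 3 heavy atoms (2 carbon, 1 oxygen; no ring), on a nitrogen on an aromatic ring in a ring: acetyl leaves and a group without a common name enters, on a nitrogen on an aromatic ring in a ring. Within the data shown here, no measured step covers this exchange, and compound 3 itself offers only a limit, so the direction can only be guessed from compounds 1 and 2, which sit well inside the dose range. Compound 4 is expected to reach 5 mg/kg, within 1.5 mg/kg to 15 mg/kg. The expected step of an at least 2.0-fold lower number from compound 3 to compound 4 (0.30 log units; that floor lies within the scatter) is therefore read only as a rough estimate.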

Compound 4, minimum effective dose: 1.25 mg/kg
Estimate against measurement, compound 4: 4.0-fold (0.60 log units) above; measured number outside the range, below it.
By their numbers in this assay, from the lowest: compounds 4, 1 and 2 (each within the scatter of the next). At a limit, above all of these: compound 3.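

In this assay, exchanging the acetyl for the nitroso group gives an at least 8.0-fold lower number from compound 3 to compound 4 (0.90 log units; beyond the scatter). This shows that the group on this ring nitrogen can change the minimum effective dose, which the earlier step, no change at the digits printed from compound 1 to compound 2 (within the scatter), with methyl in place of hydrogen, did not show. The value of compound 3 is a limit and not a number, so the printed size of the step is only a floor: the limit of > 10 mg/kg in this assay, at which 1 of the 4 values shown sits.

No pair shown isolates the chlorine on the phenyl ring, so the effect of the 3-chlorophenyl group on its own remains unknown, as does how hydrogen or methyl on this nitrogen would compare with the nitroso group on the 3-chlorophenyl compound. From the compounds shown here alone, it is also open how a larger group there, such as a propanoyl, a methylsulfonyl or a carboxylic acid, would fare.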